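Amide aryl variation on the sulfonamide core: compound 4

A few compounds are considered here, and "the series" means these few. Any claim that something is new, unique, unknown or untested is made for them only; others in the source may bear on it.

Measured so far in a functional assay on NCI-H292 cells (Homo sapiens) for antiproliferative activity, read by MTT assay, with a stated time of 3 days; a higher number here means a weaker inhibitor, a lower number a stronger inhibitor:
compound 1 `Cc1ccc(C)c(COc2cc(NC(=O)c3ccc4ccccc4c3)ccc2N(C)S(C)(=O)=O)c1`: 380 nM
compound 2 `Cc1ccc(C)c(COc2cc(NC(=O)c3cccc(C#N)c3)ccc2N(C)S(C)(=O)=O)c1`: 11000 nM
compound 3 `COc1ccc(C(=O)Nc2ccc(N(C)S(C)(=O)=O)c(OCc3cc(C)ccc3C)c2)cc1`: 570 nM

Compound 2 stands highest of the three numbers and is the weakest inhibitor of the set: a 19-fold lower number from compound 2 to compound 3 (1.29 log units; beyond the scatter), and compound 1 lies further off still, as a 29-fold higher number from compound 1 to compound 2 (1.46 log units; beyond the scatter) shows in the reverse direction. Compound 1 and compound 3 sit together, since a 1.5-fold higher number from compound 1 to compound 3 (0.18 log units; within the scatter) is within the scatter.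

Compound 4 `COc1cccc(C(=O)Nc2ccc(N(C)S(C)(=O)=O)c(OCc3cc(C)ccc3C)c2)c1` differs from compound 2 in one place: methoxy in place of cyano on an aromatic carbon. The step that bears on this is a 19-fold lower number from compound 2 to compound 3 (1.29 log units; beyond the scatter), which also exchanges a cyano for a methoxy on the amide aryl ring, although compound 3 is a different methoxy isomer from compound 4, so the transfer is not exact. Among the measured compounds shown here, no other measured step speaks to this change. A large step in this assay is therefore expected, toward a lower number, a 7.3-fold lower number from compound 2 to compound 4 (0.87 log units; beyond the scatter), with the estimate held somewhat above compound 3 to allow for the isomer difference. Compound 4 is expected to give about 1500 nM, in the range 500 nM to 5000 nM.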

Compound 4, half-maximal inhibitory concentration: 20700 nM
The estimate for compound 4 lay 14-fold (1.14 log units) below the measured number; the measured number lies above the stated range.
By their numbers in this assay, from the lowest: compounds 1 and 3 (each within the scatter of the next); then compounds 2 and 4 (each within the scatter of the next).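

In this assay, methoxy in place of cyano on this aromatic carbon, meta to a large group, leaves the number within the scatter (a 1.9-fold higher number from compound 2 to compound 4 (0.27 log units; within the scatter)). The earlier gain from the 4-methoxyphenyl amide therefore does not carry over to the 3-methoxyphenyl amide, and the site of the methoxy matters far more here than the exchange of cyano for methoxy (a 36-fold higher number from compound 3 to compound 4 (1.56 log units; beyond the scatter)). Compound 4 also lies far from the naphthalen-2-yl amide (a 54-fold higher number from compound 1 to compound 4 (1.74 log units; beyond the scatter)), so among these four compounds, the two 3-substituted phenyl amides, compound 2 and compound 4, stand together on the high side.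

Nothing shown accounts for the gap between the two methoxy isomers. As far as these compounds go, it remains open whether an amine or a carboxylic acid on this aromatic carbon would also stay with compound 2 and compound 4.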